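The source may report more compounds than this note shows. Statements on the series, on what has been measured and on what is new or still open speak of the compounds shown alone.

Measured so far:
Compound 1, `O=C(Nc1ccccc1)c1cccc(Oc2ccc3c(c2)c(=O)ncn3Cc2c(F)cc(F)cc2F)c1C(F)(F)F`, 0.84 10^-6 cm/s
Compound 2, `O=c1ncn(Cc2c(F)cc(F)cc2F)c2ccc(Oc3cccc(-c4ccc5[nH]ccc5c4)c3C(F)(F)F)cc12`, 10.5 10^-6 cm/s
Compound 3, `O=c1ncn(Cc2c(F)cc(F)cc2F)c2ccc(Oc3cccc(-c4ccc5[nH]cnc5c4)c3C(F)(F)F)cc12`, 0.4 10^-6 cm/s

In an ADME assay on Caco-2 cells (Homo sapiens) for permeability, in the apical to basolateral direction (on this read-out lower numbers stand for lower permeability and higher numbers for higher permeability), compound 3 stands lowest of the three. Its nearest neighbour is compound 1, which gives 0.84 10^-6 cm/s, and the gap is a 2.1-fold lower number from compound 1 to compound 3 (0.32 log units; beyond the scatter). Compound 2 lies furthest away: the step from it is a 26-fold lower number from compound 2 to compound 3 (1.42 log units; beyond the scatter).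

Compound 4, `Cc1cc(-c2cccc(Oc3ccc4c(c3)c(=O)ncn4Cc3c(F)cc(F)cc3F)c2C(F)(F)F)cnc1N`, has not yet been measured. It differs from compound 3 in one place: 6-amino-5-methylpyridin-3-yl in place of 1H-benzimidazol-5-yl on an aromatic carbon. The group enters on an aromatic carbon of a six-membered aromatic ring of carbon only, ortho to a trifluoromethyl group and meta to a large group.

For the measured compounds named here, two measured steps bear on this exchange, both of which replace one group at the same position. The step of a 26-fold lower number from compound 2 to compound 3 (1.42 log units; beyond the scatter) shows a large change when the 1H-benzimidazol-5-yl group arrives, and the step of a 2.1-fold lower number from compound 1 to compound 3 (0.32 log units; beyond the scatter) a modest one. Both have compound 3 at the low end, so leaving the 1H-benzimidazol-5-yl group is expected to raise the number in this assay by a modest amount: the expected step is a 2.5-fold higher number from compound 3 to compound 4 (0.40 log units; beyond the scatter). Going by the values given here, no measured compound carries an aminopyridine, so a large rise such as that seen for compound 2 cannot be assumed. Compound 4 is therefore estimated at 1 10^-6 cm/s, within a range from 0.3 10^-6 cm/s to 3.5 10^-6 cm/s.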

Compound 4, apparent permeability: 1.1 10^-6 cm/s
For compound 4 the middle estimate is 1.1-fold (0.04 log units) below the measured one; measured number inside the range.
By their numbers in this assay, from the lowest: compound 3; then compounds 1 and 4 (each within the scatter of the next); then compound 2.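

In this assay the position ortho to the trifluoromethyl group also accepts 6-amino-5-methylpyridin-3-yl, a group with one six-membered aromatic ring, which gives a 2.8-fold higher number from compound 3 to compound 4 (0.44 log units; beyond the scatter) against the 1H-benzimidazol-5-yl group but a 9.5-fold lower number from compound 2 to compound 4 (0.98 log units; beyond the scatter) against the 1H-indol-5-yl group. Against the phenylcarbamoyl group it gives a 1.3-fold higher number from compound 1 to compound 4 (0.12 log units; within the scatter) so these two groups cannot be told apart here, and compound 2 alone stands at the high end of the four. Nothing shown here gives a reason for these differences.

The compounds shown leave open what the methyl and the amino group of the pyridine each contribute. They also leave open how an unsubstituted pyridine or a morpholine would read in this assay at this position.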